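From a tert-butyl to a thiazolylmethyl amine

The source may report more compounds than this note shows. Statements on the series, on what has been measured and on what is new or still open speak of the compounds shown alone.

For the measured compounds named here, compound 3 `Cc1nc(NC(C)(C)C)nc(N[C@@H]2C[C@H](CO)[C@@H](O)[C@H]2O)c1-c1nc2ccccc2s1` is the one member of this set with a number in an ADME assay on cells (Homo sapiens) for cytotoxicity, read by polymerase chain reaction, with a stated time of 3 days; a lower number here means that less compound is tolerated, a higher number that more compound is tolerated: there compound 3 gives 12000 nM. Compound 1 `Nc1nc(Cl)c(-c2ccccn2)c(N[C@@H]2C[C@H](CO)[C@@H](O)[C@H]2O)n1` reaches only a limit in this assay, where compound 1 gives > 25000 nM. Compound 2 `Nc1nc(Cl)c(-c2cc3ccccc3s2)c(N[C@@H]2C[C@H](CO)[C@@H](O)[C@H]2O)n1` likewise reaches only a limit, and in this assay compound 2 gives > 25000 nM. These two limits, described by the limit of > 25000 nM in this assay, at which 2 of the 3 values shown sit, leave the step that the two limits leave unreadable from compound 1 to compound 2 unreadable. Compound 4 `Cc1nc(NCc2nccs2)nc(N[C@@H]2C[C@H](CO)[C@@H](O)[C@H]2O)c1-c1nc2ccccc2s1` has not been measured; it differs from compound 3 by (1,3-thiazol-2-yl)methyl in place of tert-butyl on a nitrogen on an aromatic ring. Going by the values given here, no measured step touches the same amine, and the single step that was measured cannot be read, so nothing in the data sets a direction; the expectation is therefore a step of no change at the digits printed from compound 3 to compound 4 (within the scatter) that stays within the scatter. Compound 4 is accordingly estimated at 12000 nM in this assay, between 4000 nM and 30000 nM, with a real chance that only a limit rather than a number is reported.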

Compound 4, half-maximal cytotoxic concentration: 23000 nM
The estimate for compound 4 lay 1.9-fold (0.28 log units) below the measured number; the measured number falls inside the stated range.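

In this assay, putting (1,3-thiazol-2-yl)methyl in place of tert-butyl on a nitrogen on an aromatic ring gives a 1.9-fold higher number from compound 3 to compound 4 (0.28 log units; within the scatter). For the compounds shown here, this is the first readable step in the set, as the only earlier step cannot be read, and it shows that this position accepts a five-membered aromatic ring with 2 hetero atoms in place of a group with no ring without a shift beyond the usual scatter. Compound 3 and compound 4 both give numbers, while the other values shown are limits: the limit of > 25000 nM in this assay, at which 2 of the 4 values shown sit.

One pair cannot show whether the same holds for other groups on this nitrogen, such as a benzyl, a longer alkyl chain or a free amine. It also leaves open whether a chain carrying a carboxylic acid would give a step beyond the scatter.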